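Aryl triazole variations on a shared core

This account rests on a few compounds, and the source may have more. Where it says the series, first, only, none or still open, it means among the compounds named here.

Of the compounds shown here, three have been measured in a functional assay on SW480 cells (Homo sapiens) for cytotoxicity, read by MTT assay, with a stated time of 4 days; a lower number here means a stronger inhibitor, a higher number a weaker inhibitor. Compound 1 `C=C1C(=O)[C@]23C[C@@]1(O)CC[C@H]2c1ccc(OS(=O)(=O)c2ccc(C)cc2)c(C)c1[C@@H]3Cn1cc(-c2ccccn2)nn1` gives 1970 nM. Compound 2 `C=C1C(=O)[C@]23C[C@@]1(O)CC[C@H]2c1ccc(OS(=O)(=O)c2ccc(C)cc2)c(C)c1[C@@H]3Cn1cc(-c2ccc(Br)cc2)nn1` gives 1590 nM, and compound 3 `C=C1C(=O)[C@]23C[C@@]1(O)CC[C@H]2c1ccc(OS(=O)(=O)c2ccc(C)cc2)c(C)c1[C@@H]3Cn1cc(-c2ccc(F)cc2)nn1` gives 1630 nM. The differences among them are small: a 1.2-fold lower number from compound 1 to compound 2 (0.09 log units; within the scatter), a 1.2-fold lower number from compound 1 to compound 3 (0.08 log units; within the scatter), and a 1.0-fold higher number from compound 2 to compound 3 (0.01 log units; within the scatter). Compound 3 therefore stands second highest of the three numbers, with compound 2 nearest and compound 1 furthest, and none of these gaps passes the scatter.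

Compound 4 `C=C1C(=O)[C@]23C[C@@]1(O)CC[C@H]2c1ccc(OS(=O)(=O)c2ccc(C)cc2)c(C)c1[C@@H]3Cn1cc(-c2ccc(C)cc2)nn1` has not yet been measured. Its change from compound 3 is methyl in place of fluoro on an aromatic carbon. The step that bears most directly on it is the exchange of one group on that aromatic carbon, a 1.0-fold higher number from compound 2 to compound 3 (0.01 log units; within the scatter), which produced nothing beyond the scatter; the steps of a 1.2-fold lower number from compound 1 to compound 2 (0.09 log units; within the scatter) and a 1.2-fold lower number from compound 1 to compound 3 (0.08 log units; within the scatter), which replace the whole aromatic substituent on the triazole, were likewise within the scatter. Three different substituents at this place have thus given numbers that cannot be told apart, so no step beyond the scatter is expected in this assay for a methyl here. The expected step is a 1.0-fold lower number from compound 3 to compound 4 (0.01 log units; within the scatter). Compound 4 is estimated at 1600 nM, with a range from 800 nM to 3200 nM.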

Compound 4, half-maximal inhibitory concentration: 1460 nM
Estimate against measurement, compound 4: 1.1-fold (0.04 log units) above; the measured number falls inside the stated range.
By their numbers in this assay, from the lowest: compounds 4, 2, 3 and 1 (each within the scatter of the next).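

In this assay, going by these compounds alone, methyl on an aromatic carbon para to a large group brings a carbon substituent to a place so far held only by halogens, and the number does not separate from either halogen compound (a 1.1-fold lower number from compound 3 to compound 4 (0.05 log units; within the scatter); a 1.1-fold lower number from compound 2 to compound 4 (0.04 log units; within the scatter)). The wider exchange of 4-methylphenyl for pyridin-2-yl also stays inside the scatter (a 1.3-fold lower number from compound 1 to compound 4 (0.13 log units; within the scatter)), although it is the largest of the new steps. Across compounds 1, 2, 3 and 4, then, fluoro, bromo and methyl on the phenyl ring and the pyridin-2-yl ring in its place give numbers that cannot be told apart, and no measurement alongside these numbers accounts for that.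

Whether an amine, a carboxylic acid or a longer chain at this same place would produce a step beyond the scatter stays open, since every group shown here is a single atom or a single carbon on the ring, or the pyridin-2-yl ring itself. Also open, going by these compounds, is whether this flat picture holds outside this assay or with a different group elsewhere on the shared core.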